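This account rests on a few compounds, and the source may have more. Where it says the series, first, only, none or still open, it means among the compounds named here.

Compounds measured so far:
compound 1, `C#CCNC1CCc2c(OCCCCCN3CCN(c4cccc5c4ccn5Cc4cccc(Cl)c4)CC3)cccc21`, gives 223 nM;
compound 2, `C[C@H](NCc1ccc(OCCCCCN2CCN(c3cccc4c3ccn4Cc3cccc(Cl)c3)CC2)cc1)C(N)=O`, gives 232 nM;
compound 3, `C[C@H](NCc1ccc(OCCCCCCN2CCN(c3cccc4c3ccn4Cc3cccc(Cl)c3)CC2)cc1)C(N)=O`, gives 340 nM.

These three numbers come from an assay on HEK293 cells for displacement of a labelled ligand from 5-hydroxytryptamine receptor 6 (Homo sapiens), read by scintillation counting, with a stated time of 1 h; on this read-out higher numbers stand for weaker inhibition and lower numbers for stronger inhibition. Compound 3 holds the highest number of the three, but its gap to compound 2 and its gap to compound 1 both lie within the usual scatter, so no order among the three can be read from them. The next compound, compound 4, `C#CCN(C)Cc1ccc(OCCCCCCN2CCN(c3cccc4c3ccn4Cc3cccc(Cl)c3)CC2)cc1`, differs from compound 3 in one place: methyl(propargyl)amino in place of (1-carbamoylethyl)amino on a saturated chain carbon bound to an aromatic carbon. Within the data shown here, no measured pair shows this change, so its effect is unknown from the data. Compound 1 carries a propargyl group on a nitrogen and gives a number close to those of compounds 2 and 3, which is the only hint available. The step from compound 3 to compound 4 in this assay is expected to be a 1.4-fold lower number from compound 3 to compound 4 (0.13 log units; within the scatter), that is, no step beyond the scatter in either direction. Compound 4 is therefore estimated at 250 nM in this assay, with a range from 80 nM to 800 nM.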

Compound 4, inhibition constant: 137 nM
Compound 4: the middle estimate sits 1.8-fold (0.26 log units) above what was measured, within the range that was stated.
By their numbers in this assay, from the lowest: compounds 4, 1, 2 and 3 (each within the scatter of the next, the first and the last beyond it).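

In this assay, among these compounds, placing methyl(propargyl)amino in place of (1-carbamoylethyl)amino on a saturated chain carbon bound to an aromatic carbon gives a 2.5-fold lower number from compound 3 to compound 4 (0.39 log units; beyond the scatter), so the read-out responds to the group held at this position, something the earlier compounds could not show with no single-place pair among them. The exchange removes the amide carbonyl, the hydrogen-bond donors and the defined stereocentre and adds a triple bond, and this one step cannot separate these differences. No measurement shown accounts for the step.

As far as these compounds go, it remains open whether the propargyl or the methyl on that nitrogen matters more, which a dimethylamino or a propargylamino group at this place would help to settle. From the compounds shown here alone, whether the same exchange gives a similar step on the shorter chain of compound 2 also remains open.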